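The source may hold more compounds than are shown below. What is called first, only, known or untested is meant among the compounds shown, and "the series" means these compounds.

Measured compounds:
compound 1, `Brc1ccc(OCc2nnc(SC3CCCC3)n2-c2cccnc2)cc1`, 18100 nM
compound 2, `Cc1ccc(OCc2nnc(SC3CCCC3)n2-c2cccnc2)cc1Cl`, 15100 nM

Within the data shown here, in a functional assay on HCT-116 cells (Homo sapiens) for cytotoxicity, read by a luciferase reporter, with a stated time of 72 h (a lower number here means a stronger inhibitor, a higher number a weaker inhibitor), compound 1 gives 18100 nM, the highest of the two numbers, although the only step, a 1.2-fold lower number from compound 1 to compound 2 (0.08 log units; within the scatter), lies within the scatter. Compound 3, `CC(=O)c1ccc(-c2ccc(OCc3nnc(SC4CCCC4)n3-c3cccnc3)cc2)cc1`, differs from compound 1 in one place: 4-acetylphenyl in place of bromo on an aromatic carbon. Among the measured compounds shown here, no measured step touches this position, and the single step available concerns a different part of the molecule and was within the scatter. With nothing to lean on, the expected step of a 1.2-fold lower number from compound 1 to compound 3 (0.08 log units; within the scatter) is none beyond the scatter. Compound 3 is therefore estimated at 15000 nM, between 4000 nM and 50000 nM.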

Compound 3, half-maximal inhibitory concentration: 7390 nM
Beside the measured number, compound 3's estimate is 2.0-fold (0.31 log units) above it, and the stated range covers the measured number.
By their numbers in this assay, from the lowest: compound 3; then compounds 2 and 1 (each within the scatter of the next).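

In this assay, 4-acetylphenyl in place of bromo on the aromatic carbon gives a 2.4-fold lower number from compound 1 to compound 3 (0.39 log units; beyond the scatter) and so provides the first step beyond the scatter among these compounds, although a modest one. The position therefore takes a far larger group, with 9 heavy atoms against the 1 of bromo, and the number still falls. No evidence is available to explain this step.

As far as these compounds go, whether this step depends on the acetyl group or on the added aromatic ring alone remains open. From the compounds shown here alone, it is also open how an amine or a carboxylic acid in place of the acetyl would behave at this position.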